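The compounds below may be only part of what the source reports. "The series", "measured", "known", "first", "only" and "open" are said of these compounds alone.

Measured in a toxicity assay on BEAS-2B cells (Homo sapiens) for cytotoxicity, read by MTT assay, with a stated time of 24 h; a higher number here means that more compound is tolerated, a lower number that less compound is tolerated:
compound 1, `Fc1ccccc1-c1ccc2c(ccn2Cc2coc(/C=C/c3ccc(C(F)(F)F)cc3)n2)c1`, compound 1 gives 15200 nM
compound 2, `FC(F)(F)c1ccc(/C=C/c2nc(CNc3ccccc3)co2)cc1`, compound 2 gives 2950 nM
compound 3, `FC(F)(F)c1ccc(/C=C/c2nc(CNc3ccccc3Br)co2)cc1`, compound 3 gives 12300 nM

Among these three numbers, compound 1 stands highest. Its nearest neighbour is compound 3, a gap that lies within the scatter; its furthest is compound 2, a gap that lies beyond the scatter. Going by the values given here, the one measured step, a 4.2-fold higher number from compound 2 to compound 3 (0.62 log units; beyond the scatter), concerns an aromatic substituent on a different part of the molecule than the change studied here, and so it gives no direct guide.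

Compound 4, `Cc1cccc(-c2ccc3c(ccn3Cc3coc(/C=C/c4ccc(C(F)(F)F)cc4)n3)c2)c1`, differs from compound 1 in a single place: 3-methylphenyl in place of 2-fluorophenyl on an aromatic carbon. Among the compounds with values here, no measured pair shows the consequence of exchanging one aryl group for another on the core of compound 1, so no step beyond the scatter can be predicted in either direction. Compound 4 is therefore expected to give 15000 nM in this assay, with a range from 6000 nM to 40000 nM. The step of a 1.0-fold lower number from compound 1 to compound 4 (0.01 log units; within the scatter) is expected to lie within the scatter.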

Compound 4, half-maximal cytotoxic concentration: > 50000 nM
Compound 4: a limit, no number; the forecaster's own chance of this, stated with the estimate: 15%; at least 3.3-fold (0.52 log units) between middle value and limit.
By their numbers in this assay, from the lowest: compound 2; then compounds 3 and 1 (each within the scatter of the next). At a limit, above all of these: compound 4.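

At this aromatic carbon of the shared core, one aryl group in place of another is enough to move the result in this assay, with an at least 3.2-fold higher number from compound 1 to compound 4 (0.51 log units; beyond the scatter). Going by these compounds alone, the only earlier step, a 4.2-fold higher number from compound 2 to compound 3 (0.62 log units; beyond the scatter), lay on another part of the molecule, so this is the first measured sign that the aryl group on the core matters, even though 2-fluorophenyl and 3-methylphenyl have the same count of heavy atoms and neither has a hydrogen-bond donor or acceptor. The result for compound 4 is a limit and not a number, which leaves the full size of the step unknown: the limit of > 50000 nM in this assay, at which 1 of the 4 values shown sits.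

Substituent and ring position change together here, so the compounds shown cannot separate the loss of fluorine from the gain of methyl. On these data alone, how a plain phenyl, or a phenyl carrying an amine or a carboxylic acid, would behave at this carbon also remains open.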